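This account rests on a few compounds, and the source may have more. Where it says the series, first, only, none or still open, it means among the compounds named here.

Measured so far in an ADME assay on MT2 cells (Homo sapiens) for cytotoxicity, read by MTT assay; on this read-out lower numbers stand for higher toxicity in this test and higher numbers for lower toxicity in this test:

Compound 1 `N#Cc1ccc2c(Oc3ccc(F)cc3OCCn3ccc(=O)[nH]c3=O)cccc2c1`: compound 1 gives > 100000 nM, which is a limit of this assay rather than a number.
Compound 2 `N#Cc1cc2c(Oc3ccc(F)cc3OCCn3ccc(=O)[nH]c3=O)cc(Cl)cn2c1`: compound 2 gives 15000 nM.
Compound 3 `N#Cc1ccc2c(Oc3ccccc3OCCn3ccc(=O)[nH]c3=O)cccc2c1`: compound 3 gives > 100000 nM, again a limit of this assay and not a number.

Compound 3 differs from compound 1 by hydrogen in place of fluoro on an aromatic carbon, and the step that the two limits leave unreadable from compound 1 to compound 3 cannot be read because of the limit of > 100000 nM in this assay, at which 2 of the 3 values shown sit. The difference between the cores of compound 1 and compound 2 is not broken down here. Compound 4 `N#Cc1cc2c(Oc3ccccc3OCCn3ccc(=O)[nH]c3=O)cc(Cl)cn2c1`, not yet measured, differs from compound 2 by hydrogen in place of fluoro on an aromatic carbon, the same kind of change made from compound 1 to compound 3. Since the measured example of this change yields no readable size, compound 4 is expected to sit close to compound 2, with an expected step of no change at the digits printed from compound 2 to compound 4 (within the scatter). The estimate for compound 4 in this assay is 15000 nM, expected to fall between 5000 nM and 50000 nM.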

Compound 4, half-maximal cytotoxic concentration: 39000 nM
Compound 4: the middle estimate sits 2.6-fold (0.41 log units) below what was measured, within the range that was stated.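

In this assay, hydrogen in place of fluoro on the core of compound 2 gives a 2.6-fold higher number from compound 2 to compound 4 (0.41 log units; beyond the scatter), a modest move toward lower toxicity in this test. For the compounds shown here, the same change on the core of compound 1 cannot be read, because neither end of that step is a number: the limit of > 100000 nM in this assay, at which 2 of the 4 values shown sit. Only one readable example of the change therefore exists, so the data do not show whether its size or direction carries from one core to the other.

The compounds shown leave open what other groups on that aromatic carbon, such as methyl, methoxy or an amine, would do in this test. They also leave open how a longer chain would read on either core.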